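Benzamide methyl addition in a fused pyrazole amide series

A few compounds are considered here, and "the series" means these few. Any claim that something is new, unique, unknown or untested is made for them only; others in the source may bear on it.

Measured in a functional assay on HEK293 cells for negative allosteric modulation of metabotropic glutamate receptor 5 (Homo sapiens), read by calcium flux, with a stated time of 20 min; on this read-out higher numbers stand for weaker inhibition and lower numbers for stronger inhibition:
compound 1 `CC(C)(C)c1cc2n(n1)CCN(C(=O)c1ccc3ccccc3c1)C2` gives 477 nM
compound 2 `O=C(c1ccc(Cl)cc1)N1CCn2nc(-c3ccccn3)cc2C1` gives 9470 nM
compound 3 `O=C(c1cccc(F)c1)N1CCn2nc(-c3ccc(F)cn3)cc2C1` gives 257 nM

Compound 3 has the lowest number of the three. Its gap to compound 1 lies within the scatter, so the two are not told apart; its gap to compound 2 lies well beyond it. Compound 4 `Cc1cc(F)cc(C(=O)N2CCn3nc(-c4ccc(F)cn4)cc3C2)c1` carries one change against compound 3: methyl in place of hydrogen on an aromatic carbon. For the measured compounds named here, no measured pair in this set isolates such a change, so nothing here sets its size. The step from compound 3 to compound 4 is expected to be small, a 1.2-fold lower number from compound 3 to compound 4 (0.07 log units; within the scatter), not beyond the scatter in either direction. Compound 4 is therefore estimated at 220 nM, within 70 nM to 700 nM.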

Compound 4, half-maximal inhibitory concentration: 197 nM
Beside the measured number, compound 4's estimate is 1.1-fold (0.05 log units) above it; the range from low to high includes it.
By their numbers in this assay, from the lowest: compounds 4, 3 and 1 (each within the scatter of the next, the first and the last beyond it); then compound 2.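

In this assay, for the compounds shown here, the change from 3-fluorophenyl to 3-fluoro-5-methylphenyl gives a 1.3-fold lower number from compound 3 to compound 4 (0.12 log units; within the scatter) and is the only step in this set that isolates one change. Methyl in place of hydrogen at this aromatic carbon therefore leaves the number within the scatter. Nothing available bears on why the step is this small. Going by these compounds, whether ethyl, methoxy or trifluoromethyl at this carbon would also hold the number stays open. So does whether methyl gives a similar step without the fluoro group on the same ring.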